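The compounds below may be only part of what the source reports. "The series", "measured", "known", "first", "only" and "open" are said of these compounds alone.

Measured compounds:
compound 1, `CC(O)(CS(=O)(=O)c1ccc(F)cc1)c1nc(-c2ccc(F)c(Cl)c2)no1`: > 100000 nM
compound 2, `CC(O)(CS(=O)(=O)c1ccc(Cl)cc1)c1nc(-c2ccc(F)c(Cl)c2)no1`: 35500 nM

In a functional assay on DU-145 cells (Homo sapiens) for cytotoxicity, read by MTT assay (a higher number here means a weaker inhibitor, a lower number a stronger inhibitor), compound 1 gives > 100000 nM, which is a limit of the assay and not a number; this is the limit of > 100000 nM in this assay, at which 1 of the 2 values shown sits. Only this bound is known for compound 1, so it stands at the weak end of what has been seen, without a value of its own. Compound 2 gives 35500 nM in this assay. Going by the values given here, the one measured step, an at least 2.8-fold lower number from compound 1 to compound 2 (0.44 log units; beyond the scatter), is a change of chloro in place of fluoro on an aromatic carbon.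

Compound 3, `CC(O)(CS(=O)(=O)c1ccc(F)cc1)c1nc(-c2ccc(Cl)cc2)no1`, differs from compound 1 by 4-chlorophenyl in place of 3-chloro-4-fluorophenyl on an aromatic carbon. Among the compounds with values here, no measured step touches this part of the molecule; the single step known concerns a different ring, so it offers no guide to the direction or size of the change here. With compound 1 itself at the limit, compound 3 is expected to remain a weak inhibitor in this assay, most likely again reported only as a limit. The estimate for compound 3 is 100000 nM (30000 nM to 300000 nM), which would mean a step of a number no higher from compound 1 to compound 3 (the limit leaves the size open).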

Compound 3, half-maximal inhibitory concentration: > 100000 nM
Compound 3 ended at the assay's limit; the forecaster's own chance of this, stated with the estimate: 60%; the middle value sits exactly at the limit.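

In this assay compound 3 gives > 100000 nM, which is a limit of the assay and not a number. Compound 1 also stands at a limit, so no step can be read between compound 1 and compound 3: the limit of > 100000 nM in this assay, at which 2 of the 3 values shown sit. The compounds shown leave open whether 4-chlorophenyl in place of 3-chloro-4-fluorophenyl changes the result at all, and in which direction.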